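Difluoromethoxy in place of fluoro: compound 1 to compound 3

The source may report more compounds than this note shows. Statements on the series, on what has been measured and on what is new or still open speak of the compounds shown alone.

Compound 1 `Fc1ccccc1C1Cc2nccn2C1`: 2
Compound 2 `c1ccc(C2Cc3nccn3C2)cc1`: 1.9; 2.2 (2 entries)

Within the data shown here, in a physicochemical assay for lipophilicity, at pH 7.4 (a higher number here means a more lipophilic compound, a lower number a more polar compound), compound 1 gives 2, its only numerical reading, and a further entry for it comes without a single number. Among the measured compounds shown here, the only repeat readings give a sense of the spread: the several entries of compound 2 in this assay, 1.9; 2.2 (2 entries). Compound 1 and compound 2 lie within the scatter of each other, so the numbers do not rank one above the other.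

Compound 3 `FC(F)Oc1ccccc1C1Cc2nccn2C1` carries difluoromethoxy in place of fluoro on an aromatic carbon, with the rest of the core of compound 1 unchanged: difluoromethoxy in place of fluoro on an aromatic carbon. For the measured compounds named here, no measured step covers this change, so the expectation rests on the structural change alone and remains uncertain. A modest upward step in this assay is expected, close to the scatter or a little beyond it, and a result within the scatter would not be surprising. The estimated step is a number 0.40 log units higher from compound 1 to compound 3 (beyond the scatter). For compound 3 the expected value is 2.4, with an estimated range of 2 to 2.9.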

Compound 3, distribution coefficient: 2.3
Compound 3: middle estimate off by 0.10 log units, on the high side, within the range that was stated.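

In this assay, difluoromethoxy in place of fluoro on an aromatic carbon, ortho to a group of 8 heavy atoms, gives a number 0.30 log units higher from compound 1 to compound 3 (within the scatter). Among these compounds, this is the first step read at this position, and it shows that exchanging 1 heavy atom for 4, with 1 hydrogen-bond acceptor entering, leaves compound 3 and compound 1 unranked in this read-out. The measure for that reading is the only spread of repeats available, which is of the same size as the step: the several entries of compound 2 in this assay, 1.9; 2.2 (2 entries)

The compounds shown leave open how an amine or a carboxylic acid at this same place on the six-membered aromatic ring would read in this assay, as all groups here at this place are fluoro or difluoromethoxy, apart from the unsubstituted ring of compound 2. Also open, from the compounds shown here alone, is whether the same exchange of fluoro for difluoromethoxy would give a step of like size elsewhere on that ring or on a core other than the core of compound 1.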